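The compounds below may be only part of what the source reports. "The series", "measured", "known", "first", "only" and "open" are said of these compounds alone.

Three compounds have so far been measured in a functional assay on MCF7 cells (Homo sapiens) for antiproliferative activity, read by sulforhodamine B assay, with a stated time of 48 h; a higher number here means a weaker inhibitor, a lower number a stronger inhibitor:

- compound 1, `O=C1NCCN1c1ccc(S(=O)(=O)Nc2ccc3[nH]ccc3c2)cc1`, gives 170 nM
- compound 2, `CC(C)(C)c1ccc(NS(=O)(=O)c2ccc(N3CCNC3=O)cc2)cc1`, reaches only a limit of the assay, > 1000 nM
- compound 3, `O=C1NCCN1c1ccc(S(=O)(=O)Nc2ccc(F)c(F)c2)cc1`, gives 620 nM

Among the two compounds that return a number, compound 3 stands at the higher one. Its nearest neighbour is compound 1, which sits at a clearly lower number, a gap beyond the usual scatter of this assay. The third value is not a number but a limit, (the limit of > 1000 nM in this assay, at which 1 of the 3 values shown sits), and belongs to compound 2 alone.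

The step now followed leads from compound 3 to compound 4, `Cc1ccccc1NS(=O)(=O)c1ccc(N2CCNC2=O)cc1`. The change is 2-methylphenyl in place of 3,4-difluorophenyl on a sulfonamide nitrogen. Among the compounds with values here, no measured pair in the set shows this same change, so its size cannot be read from the data directly. Compound 2, carrying another alkyl-substituted phenyl on the sulfonamide nitrogen, gave only a limit, while compound 3 with its fluorinated ring gave a number; on that basis compound 4 is expected to move toward a higher number, by a modest step of a 1.6-fold higher number from compound 3 to compound 4 (0.21 log units; within the scatter), possibly past the limit. Compound 4 is estimated at 1000 nM, with a range from 350 nM to 3000 nM.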

Compound 4, half-maximal inhibitory concentration: 280 nM
Compound 4: middle estimate off by 3.6-fold (0.55 log units), on the high side; the measured number lies below the stated range.
By their numbers in this assay, from the lowest: compounds 1 and 4 (each within the scatter of the next); then compound 3. At a limit, above all of these: compound 2.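

Read in this assay, the exchange of 3,4-difluorophenyl for 2-methylphenyl on a sulfonamide nitrogen gives a 2.2-fold lower number from compound 3 to compound 4 (0.35 log units; beyond the scatter), so this position accepts a phenyl ring that carries a methyl and no fluorine, with a number that lies beyond the scatter on the lower side. An alkyl group on this phenyl therefore does not by itself bring the poor result of compound 2, and compound 4 goes against any reading that alkyl-substituted rings fare worse here than fluorinated ones, while its number stays within the scatter of that of compound 1. Compound 2 itself remains a limit and not a number: the limit of > 1000 nM in this assay, at which 1 of the 4 values shown sits.

The compounds shown include no plain phenyl at this place, so they leave open whether the step comes from the arrival of the methyl, the departure of the two fluorines, or both. They also leave open how the same position would respond to a phenyl bearing a methoxy, an amine or a longer chain such as propyl.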